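The compounds below may be only part of what the source reports. "The series", "measured", "known", "first", "only" and "open" are said of these compounds alone.

In an ADME assay on the whole organism (Mus musculus, strain CD1) for pharmacokinetics, read by LC-MS, with a stated time of 24 h, at a dose of 5 mg/kg by the oral route (a lower number here means that a smaller share of the oral dose reaches the circulation, a higher number that a larger share of the oral dose reaches the circulation), compound 1 `O=C(O)Cn1nc(Cc2nc3cc(Cl)c(OCC(F)F)cc3[nH]2)c2ccccc2c1=O` gives 4%. Compound 2 `CCOc1cc2[nH]c(Cc3nn(CC(=O)O)c(=O)c4ccccc34)nc2cc1Cl` stands level with it, for in this assay compound 2 gives 4%. Compound 3 `O=C(O)Cn1nc(Cc2nc3cc(Cl)c(OCC4CC4)cc3[nH]2)c2ccccc2c1=O` has not yet been measured. It differs from compound 2 in one place, on a saturated chain carbon bound to an oxygen on an aromatic ring: cyclopropyl in place of methyl on a saturated chain carbon bound to an oxygen on an aromatic ring. In words, cyclopropyl stands in place of methyl, so that ethoxy becomes cyclopropylmethoxy. For the measured compounds named here, only one measured step bears on this place. That step, no change at the digits printed from compound 1 to compound 2 (within the scatter), is methyl in place of difluoromethyl on the same kind of chain carbon, and it lies within the scatter. Going by the values given here, it is thin evidence, as no measured compound carries a ring at this place. Among the compounds with values here, still, the one change seen here left the value where it was, so no step beyond the scatter is expected. The expected step in this assay is a number 1 percentage points higher from compound 2 to compound 3 (within the scatter), and its direction is not firmly indicated. For compound 3 the estimated value is 5%, with an expected range from 2% to 14%.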

Compound 3, oral bioavailability in the Mus musculus assay: 2%
Estimate against measurement, compound 3: 3 percentage points above; the range from low to high includes it.
By their numbers in the Mus musculus assay, from the lowest: compounds 3, 1 and 2 (each within the scatter of the next).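

In the Mus musculus assay the first ring at this place brought no step beyond the scatter: the change reads as a number 2 percentage points lower from compound 2 to compound 3 (within the scatter), and the comparison with the difluoromethyl compound reads as a number 2 percentage points lower from compound 1 to compound 3 (within the scatter). Methyl, difluoromethyl and cyclopropyl on a saturated chain carbon bound to an oxygen on an aromatic ring thus all give oral bioavailability values within the scatter of one another, so this readout does not separate an open chain end from a three-membered non-aromatic ring of carbon only. The same change from methyl to cyclopropyl does register in a physicochemical assay for solubility, measured as thermodynamic solubility, at pH 7.4 (on this read-out higher numbers stand for higher solubility and lower numbers for lower solubility), where it gives a modest step beyond the scatter: the measured solubility of compound 2, 917 ug/mL, and of compound 3, 395 ug/mL, a 2.3-fold lower number (0.37 log units; beyond the scatter) In the physicochemical assay compound 2 gives 917 ug/mL and compound 3 gives 395 ug/mL.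

From the compounds shown here alone, all three compounds keep the carboxylic acid and vary only this one place, so what a primary amide in its stead would do to oral bioavailability remains open. Equally open, going by these compounds, is whether a terminal amine or a longer chain on the saturated chain carbon would move the number beyond the scatter, in either direction.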